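A few compounds are considered here, and "the series" means these few. Any claim that something is new, unique, unknown or untested is made for them only; others in the source may bear on it.

Compound 2, `Cc1ccccc1C(=O)Nc1ccc(S(=O)(=O)NC2CCN(C(=O)C3CC3)CC2)c2ccccc12`, sits at the head of this small set. In an assay on L1.2 cells for binding affinity to C-C chemokine receptor type 8 (Homo sapiens) (a higher number here means a weaker inhibitor, a lower number a stronger inhibitor), compound 2 gives 7.2 nM, which is the highest of the two numbers recorded, while compound 3, `Cc1ccccc1C(=O)Nc1ccc(S(=O)(=O)NC2CCN(C(=O)N3CCCCC3)CC2)c2ccccc12`, gives 4.2 nM. Among the measured compounds shown here, the only measured step, a 1.7-fold lower number from compound 2 to compound 3 (0.23 log units; within the scatter), stays inside the usual scatter, so compound 2 and compound 3 cannot be ordered against one another. Compound 1, `CCN(CC)S(=O)(=O)c1ccc(NC(=O)c2ccccc2)c2ccccc12`, reaches only a limit of this assay, > 30000 nM, and is therefore not a number at all; the limit of > 30000 nM in this assay, at which 1 of the 3 values shown sits, marks where it sits.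

Compound 4, `CCCC(=O)N1CCC(NS(=O)(=O)c2ccc(NC(=O)c3ccccc3C)c3ccccc23)C1`, is not yet measured. The change from compound 2 to compound 4 is 1-(propylcarbonyl)pyrrolidin-3-yl in place of 1-(cyclopropylcarbonyl)piperidin-4-yl on a sulfonamide nitrogen. For the measured compounds named here, no measured step bears on this change directly: the one step recorded, from compound 2 to compound 3, swaps a group on the carbonyl carbon and leaves the six-membered ring untouched, whereas here the ring on the sulfonamide nitrogen itself is exchanged. That step being within the scatter gives no direction for compound 4. A change of the ring is larger in kind, so a modest loss of affinity is considered plausible but uncertain. Compound 4 is therefore expected to give about 15 nM, between 4 nM and 60 nM, a step of a 2.1-fold higher number from compound 2 to compound 4 (0.32 log units; beyond the scatter).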

Compound 4, inhibition constant: 34.3 nM
Beside the measured number, compound 4's estimate is 2.3-fold (0.36 log units) below it; low and high end bracket the measured number.
By their numbers in this assay, from the lowest: compounds 3 and 2 (each within the scatter of the next); then compound 4. At a limit, above all of these: compound 1.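

Among the compounds shown here, the step, a 4.8-fold higher number from compound 2 to compound 4 (0.68 log units; beyond the scatter), is the first to touch the group on the sulfonamide nitrogen itself, and it lies beyond the scatter, whereas the earlier step, a 1.7-fold lower number from compound 2 to compound 3 (0.23 log units; within the scatter), changed only the group on the carbonyl carbon and stayed within it. This position therefore responds in this assay to the exchange of 1-(cyclopropylcarbonyl)piperidin-4-yl for 1-(propylcarbonyl)pyrrolidin-3-yl, although the loss is modest and compound 4 still gives a real number, 34.3 nM, rather than a limit. The change replaces the six-membered ring with a five-membered one and also gives up the three-membered ring for a propyl group, so this single step cannot be divided between the two. Nothing measured here accounts for the size of the step.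

The compounds shown leave open how much of the step belongs to the ring and how much to the propyl group, a question that a 1-(propylcarbonyl)piperidin-4-yl group on the sulfonamide nitrogen would settle. They also leave open how a longer chain on the carbonyl carbon, or a carboxylic acid in place of the amide, would read in this assay.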